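Selenium to nitrogen on a fused bicyclic core

The compounds below may be only part of what the source reports. "The series", "measured", "known", "first", "only" and "open" are said of these compounds alone.

Compound 1 has the structure `C[Se]c1nc(N)c2ccccc2n1`; in a functional assay on HTB-54 cells (Homo sapiens) for cytotoxicity, read by MTT assay, with a stated time of 72 h (a lower number here means a stronger inhibitor of growth, a higher number a weaker inhibitor of growth), compound 1 gives 88700 nM. Compound 2 has the structure `CSc1nc(NCCCc2ccccc2)c2ccccc2n1`; in this assay compound 2 reaches only the limit > 100000 nM, which is not a number. Compound 3 has the structure `[SeH]c1nc([SeH])c2ccccc2n1`; in this assay compound 3 gives 65900 nM.

Of the two numbers shown, compound 3 has the lower one, but its gap to compound 1 lies within the usual scatter, so no order between them can be claimed. Compound 4 , `Nc1nc([SeH])nc2ccccc12`, differs from compound 3 by one nitrogen atom in place of one selenium atom, on an aromatic carbon. Going by the values given here, no step between measured compounds is available to size this change. Since compound 1 carries the same amino group and gives 88700 nM, a step of a 1.2-fold higher number from compound 3 to compound 4 (0.08 log units; within the scatter) that stays within the scatter is expected. For compound 4 the estimate is 80000 nM, in the range 30000 nM to 200000 nM.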

Compound 4, concentration for total growth inhibition: 3630 nM
Compound 4: the middle estimate sits 22-fold (1.34 log units) above what was measured; the measured number lies below the stated range.
By their numbers in this assay, from the lowest: compound 4; then compounds 3 and 1 (each within the scatter of the next). At a limit, above all of these: compound 2.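

In this assay, the amino group in place of selenium on this aromatic carbon brings an 18-fold lower number from compound 3 to compound 4 (1.26 log units; beyond the scatter). The methyl on the selenium also counts: with the amino group in place, hydrogen in place of that methyl brings a 24-fold lower number from compound 1 to compound 4 (1.39 log units; beyond the scatter). No measurement shown accounts for either step. The compounds shown leave open whether a hydroxyl or a methoxy group in place of the amino group would give a similarly low number. They also leave open whether a thiol could stand in place of the remaining selenium group.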